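The compounds below may be only part of what the source reports. "The series", "measured", "known", "first", "only" and "open" are said of these compounds alone.

Compound 1, `Clc1ccc(CO/N=C/c2c(-c3ccc4ccccc4c3)nc3sccn23)cc1Cl`, is the point of departure for the account. In an assay on HepG2 cells for agonist activity at nuclear receptor subfamily 1 group I member 3 (Homo sapiens), read by a luciferase reporter, with a stated time of 23 h (on this read-out higher numbers stand for an effect only at larger amounts of compound and lower numbers for an effect already at smaller amounts), compound 1 gives 380 nM. Two companions share its core. Compound 2, `FC(F)(F)c1ccc(CO/N=C/c2c(-c3ccc4ccccc4c3)nc3occn23)cc1`, gives 470 nM in this assay, and compound 3, `C(=N/OCc1ccc(Oc2ccccc2)cc1)\c1c(-c2ccc3ccccc3c2)nc2occn12`, is reported as "not active" (no number reported) in this assay, with no number attached. Among the two compounds that carry a number, compound 1 has the lower one, but the gap to compound 2 sits within the usual scatter, so neither can be ranked above the other on this evidence.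

The next compound to be tested is compound 4, `N#Cc1ccc(-c2nc3sccn3c2/C=N/OCc2ccc(Cl)c(Cl)c2)cc1`. Compared with compound 1, the change is 4-cyanophenyl in place of naphthalen-2-yl on an aromatic carbon; everything else in the molecule is kept. Within the data shown here, no comparison between measured compounds isolates such an exchange, so there is nothing in the data that fixes the size of the step. The naphthalen-2-yl group, with its two fused aromatic rings, gives way to a smaller single ring that brings a nitrile, and the remaining scaffold and the dichlorobenzyl oxime ether of compound 1 are unchanged.

The expectation, then, rests on the values of compound 1 and compound 2 alone. Compound 4 is expected to give about 350 nM in this assay, with the estimate spanning from 80 nM to 1600 nM, which means an expected step of a 1.1-fold lower number from compound 1 to compound 4 (0.04 log units; within the scatter) of no more than the scatter in either direction.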

Compound 4, half-maximal effective concentration: 3400 nM
Compound 4: the middle estimate sits 9.7-fold (0.99 log units) below what was measured, outside the stated range (above it).
By their numbers in this assay, from the lowest: compounds 1 and 2 (each within the scatter of the next); then compound 4.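

Among these compounds, this is the first comparison that isolates the aromatic carbon bearing the naphthalen-2-yl group of compound 1. In this assay, among the compounds shown here, 4-cyanophenyl at this place gives an 8.9-fold higher number from compound 1 to compound 4 (0.95 log units; beyond the scatter), so the read-out responds to the group here, a step beyond the scatter that the earlier compounds, with naphthalen-2-yl throughout, could not reveal. Even so, compound 4 still gives a number, 3400 nM, so this exchange, which replaces two six-membered aromatic rings with one and brings in a nitrile, does not remove measurable agonist activity, though nothing measured on these compounds accounts for the size of the step.

The compounds shown leave open whether the step goes with the lost aromatic ring or with the nitrile, a question that a plain phenyl group at this place would help to separate. Also open, on these data alone, is how far the step carries over to the core of compound 2, and how a group of another kind, such as an amine or a carboxylic acid on the phenyl ring, would read out here.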